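The compounds below may be only part of what the source reports. "The series", "measured", "known", "first", "only" and "open" are said of these compounds alone.

Compound 1 `CN(C)CCNc1nc(NCc2ccco2)c2ccccc2n1` carries a 2-(dimethylamino)ethyl amino chain on the shared core and, in a functional assay on DU-145 cells (Homo sapiens) for cytotoxicity, read by MTT assay, with a stated time of 2 days (on this read-out higher numbers stand for weaker inhibition and lower numbers for stronger inhibition), compound 1 gives "not determined" (no result reported), so no number stands for it. For the measured compounds named here, the only measured point is compound 2 `COc1ccc(Nc2nc(NCc3ccco3)c3cc(F)ccc3n2)cc1`, which differs from compound 1 in more than one place and so gives no step; in this assay compound 2 gives 11600 nM, a weak effect on the scale used. Compound 3 `CCN(CC)CCNc1nc(NCc2ccco2)c2ccccc2n1` is the closest relative of compound 1, reached by a single change: diethylamino in place of dimethylamino on a saturated chain carbon, two bonds along the chain from a nitrogen on an aromatic ring. Since compound 1 has no value, the size of this step cannot be read from any measured pair, and on the ground of the two structures alone no step beyond the scatter of this assay is expected in either direction. Taking the weak activity of compound 2 at 11600 nM as the only anchor for the series, compound 3 is expected to sit in this assay near 10000 nM, within a range from 2000 nM to 50000 nM.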

Compound 3, half-maximal inhibitory concentration: > 100000 nM
Compound 3 gave a limit, no number; the forecaster's own chance of this, stated with the estimate: 20%; middle value at least 10-fold (1.00 log units) from the limit.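

For the compounds shown here, compound 1 has no number in this assay, and so no step to compound 3 can be read. The result for compound 3, > 100000 nM, is a limit and not a number. The compounds shown leave open whether the change from dimethylamino to diethylamino shifts the read-out in this assay at all, and in which direction.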